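The source may report more compounds than this note shows. Statements on the series, on what has been measured and on what is new or still open speak of the compounds shown alone.

Measured in an ADME assay for metabolic stability, read by HPLC, in simulated gastric fluid, with a stated time of 12 h, at pH 1.2; on this read-out lower numbers stand for a shorter-lived compound and higher numbers for a longer-lived compound:
- compound 1 `O=C(N[C@H](CO)C(=O)O)[C@@H]1C[C@H](O)CN1`: > 12 h
- compound 2 `O=C(O)[C@H](CO)NC(=O)[C@H]1C[C@@H](O)CN1`: > 12 h

Compound 1 gives > 12 h, which is a limit of the assay and not a number. Compound 2 gives > 12 h, which is also a limit and not a number. Compound 2 therefore stands with compound 1 at the limit of > 12 h in this assay, at which 2 of the 2 values shown sit, and no exact half-life is known for either.

Compound 3 `O=C(O)[C@H](CO)NC(=O)[C@@H]1C[C@@H](O)CN1` has not yet been measured. Its change from compound 2 is this: the two compounds have the same atoms and bonds and differ only in configuration as drawn: 1 of 3 stereo elements differ; a stereocentre at a saturated ring carbon is drawn R in compound 2 and S in compound 3. The atoms and bonds stay the same, and only a stereocentre at a saturated ring carbon is drawn differently.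

For the measured compounds named here, the one measured step that bears on this is a step that the two limits leave unreadable from compound 1 to compound 2. That step also concerns configuration alone, as the fact that compounds 1 and 2 differ only in the configuration as drawn shows, although there all stereocentres are inverted rather than one. Its size cannot be read, so it offers no direction, and no change beyond the usual scatter is expected in this assay. Compound 3 will most likely be reported as a limit too.

The expected step is a step that the limit leaves unreadable from compound 2 to compound 3. For compound 3 the estimated half-life is 16 h, with an expected range from 10 h to 30 h.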

Compound 3, half-life: > 12 h
Compound 3: no number, only a limit; the forecaster's own chance of this, stated with the estimate: 90%; the middle value is on the limit's open side.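

Compound 3 gives > 12 h, which is a limit of the assay and not a number. For the compounds shown here, with all three results at the same limit, no step among compound 1, compound 2 and compound 3 can be read. The compounds shown leave open how long each actually lasts in this assay, and whether their differences in configuration change the half-life at all.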